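This account rests on a few compounds, and the source may have more. Where it says the series, first, only, none or still open, it means among the compounds named here.

Series so far:
compound 1 `O=C(CCCCC(CCSC(=O)c1ccccc1)SC(=O)c1ccccc1)Nc1ccccc1`: 3.12%
compound 2 `O=C(CCCCC(CCSC(=O)c1ccccc1)SC(=O)c1ccccc1)Nc1ccccc1Cl`: "not active" (no number reported)

Both were tested in a functional assay on HO8910 cells (Homo sapiens) for inhibition, read by MTT assay, with a stated time of 24 h, tested at 0.1 ug/mL; a lower number here means less inhibition of growth, a higher number more inhibition of growth at the concentration tested. Compound 2 has no single number and is reported only as "not active" (no number reported), so its distance from compound 1 cannot be expressed as a step. Compound 3 `O=C(CCCCC(CCSC(=O)c1ccccc1)SC(=O)c1ccccc1)Nc1ccc(Cl)cc1` has not yet been measured. The structural change is 4-chlorophenyl in place of 2-chlorophenyl on an amide-type nitrogen, with 4-chlorophenyl in place of 2-chlorophenyl on an amide-type nitrogen. With compound 1 at 3.12% and compound 2 at "not active" (no number reported), no step beyond the scatter is expected in this assay. Compound 3 is expected at 3%, with an estimated range of 0% to 12%.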

Compound 3, percent growth inhibition at one concentration: 3.68%
Beside the measured number, compound 3's estimate is 0.7 percentage points below it, and the stated range covers the measured number.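

Chloro in place of hydrogen on an aromatic carbon, as 4-chlorophenyl on the amide-type nitrogen, gives in this assay a number 0.6 percentage points higher from compound 1 to compound 3 (within the scatter), so this placement of chloro shows no separation from the unsubstituted phenyl of compound 1. The change from 2-chlorophenyl to 4-chlorophenyl cannot be read as a step, with compound 2 reported as "not active" (no number reported) and only compound 3 carrying a number. Nothing available bears on the reason for this result.

Open, going by these compounds, is whether 4-aminophenyl or 4-carboxyphenyl on the amide-type nitrogen would give a reading beyond the scatter in this assay and whether a longer chain in the shared core would do so.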